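Aryl urea series: isopropyl to trifluoromethyl on the aryl ring

This account rests on a few compounds, and the source may have more. Where it says the series, first, only, none or still open, it means among the compounds named here.

Measured so far:
- compound 1 `CC(C)c1ccccc1NC(=O)N[C@H](C)c1ccccc1` gives 103% in an ADME assay on the whole organism with Oryza sativa as the target, tested at 0.1 uM; on this read-out lower numbers stand for a stronger effect and higher numbers for a weaker effect at the one concentration tested
- compound 2 `CC(C)c1ccccc1NC(=O)N[C@@H](C)c1ccccc1` gives 99% in this assay
- compound 3 `CCCCc1ccc(NC(=O)N[C@@H](C)c2ccccc2)cc1` gives 98% in this assay

All three numbers sit close together. Among the measured compounds shown here, the one single-point step, a number 4 percentage points lower from compound 1 to compound 2 (within the scatter), rests on the fact that compounds 1 and 2 differ only in the configuration as drawn and shows no change beyond the scatter. Compound 2 lies within the scatter of both compound 1 and compound 3 in this assay; nothing among the three separates them.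

The next compound, compound 4 `C[C@H](NC(=O)Nc1ccccc1C(F)(F)F)c1ccccc1`, is reached from compound 2 by trifluoromethyl in place of isopropyl on an aromatic carbon, the entering group sitting on an aromatic carbon of a six-membered aromatic ring of carbon only, ortho to a large group. For the measured compounds named here, no measured step touches this group: the only step known is the configuration step from compound 1 to compound 2, which leaves the aryl substituent untouched, and compound 3 differs in more than one place. There is thus no measured basis for a step of any size, and with all three numbers so close the expectation is no step beyond the scatter in this assay.

The step from compound 2 to compound 4 is expected to be no change at the digits printed from compound 2 to compound 4 (within the scatter). Compound 4 is therefore estimated at 99%, within 88% to 108%.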

Compound 4, a percentage reported as activity, at one concentration (the size of the read-out at that concentration, not a potency): 97%
Estimate against measurement, compound 4: 2 percentage points above; measured number inside the range.
By their numbers in this assay, from the lowest: compounds 4, 3, 2 and 1 (each within the scatter of the next).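

Trifluoromethyl in place of isopropyl on an aromatic carbon, ortho to a large group, is the first single-place change to the aryl substituent in this series, and in this assay it gives a step that stays small: a number 2 percentage points lower from compound 2 to compound 4 (within the scatter). Among the compounds shown here, the earlier compounds offered only a configuration step, so this is the first sign that the read-out at this position does not respond to this exchange of groups, at the one concentration tested. Nothing at hand bears on why this exchange leaves the number within the scatter.

The compounds shown leave open whether any group at this position can give a step beyond the scatter in this assay, for example an amine, a carboxylic acid or a longer chain in place of isopropyl. Also open, from the compounds shown here alone, is whether the trifluoromethyl compound drawn with the opposite configuration at the stereocentre would stay within the scatter of compound 4, as the isopropyl pair of compound 1 and compound 2 does.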